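This account rests on a few compounds, and the source may have more. Where it says the series, first, only, none or still open, it means among the compounds named here.

Three close relatives built on a shared core have been tested in an ADME assay on SW480 cells (Homo sapiens) for cytotoxicity, read by MTT assay, with a stated time of 72 h; on this read-out lower numbers stand for stronger inhibition and higher numbers for weaker inhibition. Compound 1 `CCc1cccc(NC(=O)c2cccc(/C=C3\CC(=O)N(Cc4ccccc4)C3=O)c2)c1` gives 91500 nM in this assay. Compound 2 `Cc1ccc(NC(=O)c2cccc(/C=C3\CC(=O)N(c4ccccc4)C3=O)c2)cc1C` gives only a limit in this assay, > 100000 nM. Compound 3 `COc1ccc(NC(=O)c2cccc(CC3CC(=O)N(c4ccc(C)cc4)C3=O)c2)cc1` also gives only a limit in this assay, > 100000 nM. Compound 2 therefore stands at the limit of > 100000 nM in this assay, at which 2 of the 3 values shown sit, a place shared with compound 3, while compound 1 is the only one of the three to give a number. Among the compounds with values here, no step between any two of these measured compounds has been worked out.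

Compound 4 `O=C(c1cccc(/C=C2\CC(=O)N(c3ccccc3)C2=O)c1)N1CCCC1` has not yet been tested. It differs from compound 2 at a single place: pyrrolidin-1-yl in place of (3,4-dimethylphenyl)amino on a carbonyl carbon. Within the data shown here, with no measured step to lean on, no move beyond the usual scatter is expected in either direction. The step expected from compound 2 to compound 4 is an at least 1.1-fold lower number from compound 2 to compound 4 (0.04 log units; that floor lies within the scatter). Compound 4 is estimated at 90000 nM in this assay, with a range from 40000 nM to 200000 nM, and a limit rather than a number is quite likely.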

Compound 4, half-maximal inhibitory concentration: > 100000 nM
Compound 4 was reported as a limit (the forecaster's own chance of this, stated with the estimate: 55%); middle value at least 1.1-fold (0.04 log units) away from the limit.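

Within the data shown here, compound 2 and compound 4 each give only a limit rather than a number in this assay, so no step between them can be read. Going by these compounds, whether pyrrolidin-1-yl in place of (3,4-dimethylphenyl)amino on a carbonyl carbon changes the read-out at all remains open.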